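The source may report more compounds than this note shows. Statements on the series, on what has been measured and on what is new or still open speak of the compounds shown alone.

Compound 1 `Nc1ccccc1NC(=O)C1(S(=O)(=O)c2ccc(NC3CCCCC3)cc2)CCC2(CCNCC2)C1` carries a (2-aminophenyl)amino group on a carbonyl carbon whose other neighbours are a saturated ring carbon. In a functional assay on blood (Homo sapiens), with a stated time of 60 min, in the presence of a further agent that is not named here (a higher number here means that more compound is needed for the effect, a lower number that less compound is needed), compound 1 gives only a limit of the assay, <= 400 nM. Compound 3 `O=C(Oc1ccccc1)C1(S(=O)(=O)c2ccc(NC3CCCCC3)cc2)CCC2(CCNCC2)C1` differs by one change, (phenoxy in place of (2-aminophenyl)amino on a carbonyl carbon). In this assay compound 3 also gives only a limit, > 15000 nM. The step is an at least 37-fold higher number from compound 1 to compound 3 (1.57 log units; beyond the scatter), and its exact size is open because it rests on the limit of <= 400 nM in this assay, at which 1 of the 3 values shown sits, and on (the limit of > 15000 nM in this assay, at which 1 of the 3 values shown sits). Compound 2 `COc1ccc(S(=O)(=O)C2(C(=O)Nc3ccccc3N)CCC3(CCNCC3)C2)cc1Cl` has a different core; the difference between the two cores is not broken down here. In this assay compound 2 gives 7500 nM. Compound 4 `COc1ccc(S(=O)(=O)C2(C(=O)Oc3ccccc3)CCC3(CCNCC3)C2)cc1Cl` arises from compound 2 by the same change, (phenoxy in place of (2-aminophenyl)amino on a carbonyl carbon), at the same kind of place. For compound 4 the expected step is a 13-fold higher number from compound 2 to compound 4 (1.12 log units; beyond the scatter), a large loss, resting on the measured step of an at least 37-fold higher number from compound 1 to compound 3 (1.57 log units; beyond the scatter). Compound 4 is thus estimated at 100000 nM, most likely reported as a limit.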

Compound 4, half-maximal effective concentration: 3700 nM
The estimate for compound 4 lay 27-fold (1.43 log units) above the measured number, outside the stated range (below it).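

In this assay, phenoxy in place of (2-aminophenyl)amino on a carbonyl carbon gives a 2.0-fold lower number from compound 2 to compound 4 (0.31 log units; beyond the scatter), so the large loss seen on the core of compound 1 does not carry over to the core of compound 2, and the two results clearly differ: the same change on two cores in this assay, an at least 37-fold higher number (1.57 log units; beyond the scatter) from compound 1 to compound 3 and a 2.0-fold lower number (0.31 log units; beyond the scatter) from compound 2 to compound 4, at least 76-fold (1.88 log units) apart, beyond the scatter of two such steps. The gap has no exact size, as compound 1 gives only a limit: the limit of <= 400 nM in this assay, at which 1 of the 4 values shown sits. Compound 3 also gives only a limit: the limit of > 15000 nM in this assay, at which 1 of the 4 values shown sits.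

Two pairs cannot tell which part of the two cores turns the outcome around. Also open, going by these compounds, is whether a carboxylic acid or a methylamino group in the same place would behave alike on both cores.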